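Ethoxycarbonyl for propargyl on the shared core

This account rests on a few compounds, and the source may have more. Where it says the series, first, only, none or still open, it means among the compounds named here.

Compound 1 `C#CCn1c2ccc([N+](=O)[O-])cc2c(=O)n1Cc1ccccc1` is the reference here. In an ADME assay on L929 cells (Mus musculus) for cytotoxicity, read by resazurin assay, with a stated time of 48 h (a higher number here means that more compound is tolerated, a lower number that less compound is tolerated), compound 1 gives 195000 nM, which is the highest of the two plain numbers measured; the nearest is compound 2 `O=c1c2cc([N+](=O)[O-])ccc2n(CCCBr)n1Cc1ccccc1`, which gives 25200 nM, and the step of a 7.7-fold lower number from compound 1 to compound 2 (0.89 log units; beyond the scatter) lies beyond the scatter. Compound 3 `CC(=O)OCCn1c2ccc([N+](=O)[O-])cc2c(=O)n1Cc1ccccc1` reaches only a limit of the assay, > 256000 nM (the limit of > 256000 nM in this assay, at which 1 of the 3 values shown sits). The step of an at least 1.3-fold higher number from compound 1 to compound 3 (0.11 log units; that floor lies within the scatter) therefore has a floor within the scatter, while an at least 10-fold higher number from compound 2 to compound 3 (1.00 log units; beyond the scatter) is beyond it.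

Compound 4 `CCOC(=O)n1c2ccc([N+](=O)[O-])cc2c(=O)n1Cc1ccccc1` differs from compound 1 in one place: ethoxycarbonyl in place of propargyl on an aromatic nitrogen. For the measured compounds named here, of the measured steps, the one to compound 3 bears most on this change, since both replace the propargyl with an oxygen-bearing ester-type group; the bromoalkyl step to compound 2 went the other way. The expectation for compound 4 in this assay is thus a number at or somewhat above that of compound 1, likely within the scatter, so the estimated step is a 1.2-fold higher number from compound 1 to compound 4 (0.07 log units; within the scatter). Compound 4 is expected to give about 230000 nM, between 110000 nM and 300000 nM, possibly reaching the assay limit.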

Compound 4, concentration lethal to 50% of the cells: 122000 nM
Estimate against measurement, compound 4: 1.9-fold (0.28 log units) above; measured number inside the range.
By their numbers in this assay, from the lowest: compound 2; then compounds 4 and 1 (each within the scatter of the next). At a limit, above all of these: compound 3.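

In this assay, ethoxycarbonyl in place of propargyl on this aromatic nitrogen stays within the scatter, with a 1.6-fold lower number from compound 1 to compound 4 (0.20 log units; within the scatter). Ethoxycarbonyl and 2-acetoxyethyl do not read alike here, with an at least 2.0-fold lower number from compound 3 to compound 4 (0.32 log units; beyond the scatter), so a carbonyl-bearing group on this nitrogen does not by itself fix the number, while 3-bromopropyl remains apart, with a 4.8-fold higher number from compound 2 to compound 4 (0.68 log units; beyond the scatter). The comparison with compound 3 rests on a limit and not on a number: the limit of > 256000 nM in this assay, at which 1 of the 4 values shown sits.

The compounds shown leave open whether an amine or a carboxylic acid on this nitrogen would also stay within the scatter of compound 1. They also leave open whether a longer chain carrying the ethoxycarbonyl would read more like compound 4 or like compound 3.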